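A few compounds are considered here, and "the series" means these few. Any claim that something is new, unique, unknown or untested is made for them only; others in the source may bear on it.

Measured so far:
compound 1 `COc1ccc(-c2cc(C(=O)N/N=C/c3ccccc3O)n(Cc3ccc(Cl)nc3)n2)cc1` — 70000 nM
compound 2 `O=C(N/N=C/c1ccccc1O)c1cc(-c2ccccc2)nn1Cc1ccccc1` — 44000 nM
compound 3 `O=C(N/N=C/c1ccccc1O)c1cc(-c2ccc(Cl)cc2)nn1Cc1ccccc1` — 25000 nM

These three compounds share one core and differ only in the groups hung on it. In a functional assay on A549 cells (Homo sapiens) for cytotoxicity, read by MTT assay, with a stated time of 48 h (a higher number here means a more soluble compound, a lower number a less soluble compound), compound 3 gives the lowest of the three numbers: its nearest neighbour is compound 2, and the gap between them, a 1.8-fold lower number from compound 2 to compound 3 (0.25 log units; within the scatter), lies within the scatter, so the two cannot be told apart with confidence. Compound 1 sits further away, beyond the scatter.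

Compound 4 `COc1ccc(-c2cc(C(=O)N/N=C/c3ccccc3O)n(Cc3ccccc3)n2)cc1` is not yet measured. It arises from compound 3 by one change: methoxy in place of chloro on an aromatic carbon. Among the measured compounds shown here, only one measured step touches the same ring position, namely a 1.8-fold lower number from compound 2 to compound 3 (0.25 log units; within the scatter), where chloro entered in place of hydrogen and the number barely moved. For the measured compounds named here, no measured pair shows methoxy entering at that position directly; compound 1 does carry the methoxyphenyl group but differs from compound 4 elsewhere, so its value can only hint that the methoxy-bearing compounds need not have low numbers. Taken together, a modest rise toward the values of compound 1 and compound 2 is expected for compound 4 in this assay, roughly a 1.8-fold higher number from compound 3 to compound 4 (0.26 log units; within the scatter). The estimate for compound 4 is therefore 45000 nM, with a likely range from 20000 nM to 100000 nM.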

Compound 4, solubility: 23000 nM
The estimate for compound 4 lay 2.0-fold (0.29 log units) above the measured number; the range from low to high includes it.
By their numbers in this assay, from the lowest: compounds 4, 3, 2 and 1 (each within the scatter of the next, the first and the last beyond it).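

In this assay, the change from 4-chlorophenyl to 4-methoxyphenyl gives a 1.1-fold lower number from compound 3 to compound 4 (0.04 log units; within the scatter), and methoxy in place of hydrogen on the same aromatic carbon gives a 1.9-fold lower number from compound 2 to compound 4 (0.28 log units; within the scatter), so hydrogen, chloro and methoxy at this carbon, para to a large group, cannot be told apart in this read-out. Among the compounds shown here, the one step here that lies beyond the scatter belongs to a different place in the molecule: phenyl in place of 6-chloropyridin-3-yl on the saturated chain carbon bound to an aromatic nitrogen gives a 3.0-fold lower number from compound 1 to compound 4 (0.48 log units; beyond the scatter), a modest change that is the first clear difference tied to a single swap in this set. No supporting measurement is available to explain either result.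

As far as these compounds go, whether an amine, a carboxylic acid or a longer chain such as butoxy on that same aromatic carbon would give a number outside the scatter remains open. From the compounds shown here alone, the step at the chain carbon also rests on a single pair, so it is unknown whether 6-chloropyridin-3-yl would give a similar step alongside a 4-chlorophenyl or an unsubstituted phenyl group.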